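Working notes: urea aryl swap on the shared core

The source may report more compounds than this note shows. Statements on the series, on what has been measured and on what is new or still open speak of the compounds shown alone.

Measured so far in a functional assay on A549 cells (Homo sapiens) for antiproliferative activity, read by MTT assay, with a stated time of 72 h; a lower number here means a stronger inhibitor, a higher number a weaker inhibitor:
- compound 1, `CN1CCN(Cc2ccc(NC(=O)Nc3ccc4ncnc(Nc5ccc(F)c(Cl)c5)c4c3)cc2)CC1`: compound 1 gives 3480 nM
- compound 2, `C#Cc1cccc(Nc2ncnc3ccc(NC(=O)Nc4ccc(CN5CCN(C)CC5)cc4)cc23)c1`: compound 2 gives 5170 nM
- compound 3, `CN1CCN(Cc2ccc(NC(=O)Nc3ccc4ncnc(Nc5cccc(C(F)(F)F)c5)c4c3)cc2)CC1`: compound 3 gives 1650 nM

Compound 3 gives the lowest number of the three; the step of a 2.1-fold lower number from compound 1 to compound 3 (0.32 log units; beyond the scatter) and the step of a 3.1-fold lower number from compound 2 to compound 3 (0.50 log units; beyond the scatter) both lie beyond the scatter, while the step of a 1.5-fold higher number from compound 1 to compound 2 (0.17 log units; within the scatter) does not. Compound 4, `COc1ccc(NC(=O)Nc2ccc3ncnc(Nc4cccc(C(F)(F)F)c4)c3c2)cc1`, keeps the aniline of compound 3 and changes the other end of the urea: methoxy in place of (4-methylpiperazin-1-yl)methyl on an aromatic carbon. Within the data shown here, none of the measured steps touches this position; all three vary the group on the nitrogen on the aromatic ring, so they give no direct guide to the size or direction of this change. With nothing to show that the urea aryl substituent drives the number, the expectation for compound 4 is a value close to that of compound 3, with a wide margin either way. The estimated step of a 1.5-fold higher number from compound 3 to compound 4 (0.18 log units; within the scatter) is expected to fall within the scatter. For compound 4 the estimate is 2500 nM, with a range from 700 nM to 9000 nM.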

Compound 4, half-maximal inhibitory concentration: 9470 nM
For compound 4 the middle estimate is 3.8-fold (0.58 log units) below the measured one; measured number outside the range, above it.
By their numbers in this assay, from the lowest: compound 3; then compounds 1, 2 and 4 (each within the scatter of the next, the first and the last beyond it).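

The aryl end of the urea is not a silent position in this assay: methoxy in place of (4-methylpiperazin-1-yl)methyl gives a 5.7-fold higher number from compound 3 to compound 4 (0.76 log units; beyond the scatter). Among these compounds, the earlier steps varied only the aniline group, so this is the first sign that the far end of the urea also moves the number. Here the larger group, with its six-membered ring bearing two hetero atoms, goes with the lower number, though this rests on a single pair. Nothing shown bears on why the number changes.

A single step cannot separate losing the ring from gaining methoxy, and a dimethylaminomethyl group or a morpholin-4-ylmethyl group at this place would help to tell these apart. From the compounds shown here alone, it also remains open whether the same swap gives a similar step with 3-ethynylphenyl or 3-chloro-4-fluorophenyl on the aniline.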